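A few compounds are considered here, and "the series" means these few. Any claim that something is new, unique, unknown or untested is made for them only; others in the source may bear on it.

In a functional assay for inhibition, with Homo sapiens as the target (a higher number here means weaker binding, a lower number tighter binding), the measured compounds give these values:
- compound 1 `O=C(O)CC/C=C\CC1COC(c2ccccc2Cl)OC1c1cccnc1` gives 759 nM
- compound 2 `Cc1ccc(C#N)c(OC(C)(C)C2OCC(C/C=C\CCC(=O)O)C(c3cccnc3)O2)c1` gives 15.9 nM
- compound 3 `CC(C)(Oc1ccccc1[N+](=O)[O-])C1OCC(C/C=C\CCC(=O)O)C(c2cccnc2)O1` gives 11.2 nM

Compound 3 at 11.2 nM sits within the scatter of compound 2, while compound 1 at 759 nM stands far higher. Compound 4 `CC(C)(Sc1ccccc1)C1OCC(C/C=C\CCC(=O)O)C(c2cccnc2)O1` has not been measured yet. It carries phenylsulfanyl in place of 2-nitrophenoxy on a saturated chain carbon bound to two saturated chain carbons and a saturated ring carbon. Going by the values given here, the only measured step that bears on this change is a 1.4-fold lower number from compound 2 to compound 3 (0.15 log units; within the scatter) and it stayed within the scatter. Among the compounds with values here, that step swapped one ring-bearing group for another, but no measured compound carries phenylsulfanyl, so the present change is untested and the range must stay wide. The expectation in this assay is therefore no step beyond the scatter, with an estimated size of a 1.6-fold higher number from compound 3 to compound 4 (0.21 log units; within the scatter) as the most likely outcome. Compound 4 is estimated at 18 nM with an expected range from 6 nM to 55 nM in this measurement.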

Compound 4, dissociation constant: 200 nM
Estimate against measurement, compound 4: 11-fold (1.05 log units) below; the whole stated range lies below it.
By their numbers in this assay, from the lowest: compounds 3 and 2 (each within the scatter of the next); then compound 4; then compound 1.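

In this assay, going by these compounds alone, the groups on this saturated chain carbon are not interchangeable: although the two oxygen-linked groups of the earlier compounds stayed within the scatter of each other, phenylsulfanyl brings an 18-fold higher number from compound 3 to compound 4 (1.25 log units; beyond the scatter) and, measured against the other oxygen-linked group, a 13-fold higher number from compound 2 to compound 4 (1.10 log units; beyond the scatter). Even so, the group carrying phenylsulfanyl keeps an advantage over the 2-chlorophenyl-bearing comparison compound, with a 3.8-fold lower number from compound 1 to compound 4 (0.58 log units; beyond the scatter). No measurement here accounts for the loss.

The change replaces the oxygen link with sulfur and also removes the nitro group from the ring, so these two differences cannot be told apart. A plain phenoxy group or a 2-nitrophenylsulfanyl group at this place would separate them.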